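The compounds below may be only part of what the source reports. "The series", "measured", "known", "first", "only" and "open" are said of these compounds alone.

Working notes on the series, values from a physicochemical assay for lipophilicity; a lower number here means a more polar compound, a higher number a more lipophilic compound:

- compound 1 `Ic1ccccc1-c1ncco1`: 2.3
- compound 2 `CCSc1ccccc1C1=NC(c2ccccc2)CO1`: 4.04
- compound 3 `Fc1cccc(F)c1C1=NC(c2ccccc2)CO1`: 3.01

Compound 2, at 4.04, stands highest of the three. Compound 3 comes next at 3.01, and compound 1 lies furthest down at 2.3. Both gaps from compound 2 lie beyond the scatter.

The next compound to be read is compound 4 `c1ccc(Oc2ccccc2C2=NC(c3ccccc3)CO2)cc1`. It differs from compound 2 by phenoxy in place of ethylsulfanyl on an aromatic carbon, ortho to a large group: phenoxy in place of ethylsulfanyl on an aromatic carbon.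

Going by the values given here, no measured pair shows this change, or any other single change, so the size of the step cannot be read from the data. The expectation starts from compound 2 at 4.04 and rests otherwise on the count alone: the entering phenoxy has more heavy atoms, and its six-membered aromatic ring is of carbon only. A moderate rise in this assay, beyond the scatter, is therefore expected, though with wide uncertainty. The expected step is a number 0.66 log units higher from compound 2 to compound 4 (beyond the scatter). For compound 4 the estimated value is 4.7, with an expected range of 4.2 to 5.3.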

Compound 4, partition coefficient: 5.61
Beside the measured number, compound 4's estimate is 0.91 log units below it; the measured number lies above the stated range.
By their numbers in this assay, from the lowest: compound 1; then compound 3; then compound 2; then compound 4.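

Going by these compounds alone, the exchange of ethylsulfanyl for phenoxy, on an aromatic carbon ortho to a large group, gives the first single-place comparison: in this assay the step is a number 1.57 log units higher from compound 2 to compound 4 (beyond the scatter) and counts as large. The read-out is therefore sensitive to the group at this position, even with no change in hydrogen-bond donors, hydrogen-bond acceptors or net charge between the leaving and entering groups. What does differ is the larger heavy-atom count of phenoxy and its six-membered aromatic ring of carbon only, but nothing measured bears on why the step has this size, and one pair cannot separate those two differences.

On these data alone, it remains open whether the rise follows the aromatic ring or the heavy-atom count, a question that a cyclohexyloxy group or a longer chain such as hexyloxy on the same carbon could address. Also open, as far as these compounds go, are the effect of an amine or a carboxylic acid at this place and whether the same exchange gives a similar step on the core of compound 1.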